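A Chlorophenyl Swap Carried onto a Hydroxy-Bearing Core

A few compounds are considered here, and "the series" means these few. Any claim that something is new, unique, unknown or untested is made for them only; others in the source may bear on it.

Three compounds built on a chain of three linked benzene rings with a benzimidazole at one end were tested in a functional assay on Gurav cells (Homo sapiens) for inhibition, read by sulforhodamine B assay; on this read-out lower numbers stand for stronger inhibition of growth and higher numbers for weaker inhibition of growth. Compound 1 `Cc1ccc2[nH]c(-c3ccc(-c4ccc(-c5ccc(N(C)C)cc5)cc4)cc3)nc2c1` gives 6240 nM in this assay. Compound 2 `Cc1ccc2[nH]c(-c3ccc(-c4ccc(-c5cccc(Cl)c5)cc4)cc3)nc2c1` differs from compound 1 by 3-chlorophenyl in place of 4-(dimethylamino)phenyl on an aromatic carbon. In this assay compound 2 gives 2120 nM; this change produced a 2.9-fold lower number from compound 1 to compound 2 (0.47 log units; beyond the scatter). Compound 3 `CN(C)c1ccc(-c2ccc(-c3ccc(-c4nc5c(O)cccc5[nH]4)cc3)cc2)cc1` carries a different core, set apart from compound 1 by 4-hydroxy-1H-benzimidazol-2-yl in place of 5-methyl-1H-benzimidazol-2-yl on an aromatic carbon. In this assay compound 3 gives 8210 nM, which amounts to a 1.3-fold higher number from compound 1 to compound 3 (0.12 log units; within the scatter).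

Compound 4 `Oc1cccc2[nH]c(-c3ccc(-c4ccc(-c5cccc(Cl)c5)cc4)cc3)nc12` has not yet been measured. It differs from compound 3 by 3-chlorophenyl in place of 4-(dimethylamino)phenyl on an aromatic carbon, the same change that turned compound 1 into compound 2; the change occurs twice among these compounds, and the surroundings of the change are the same in both cases. The step from compound 3 to compound 4 in this assay is expected to be a 2.8-fold lower number from compound 3 to compound 4 (0.45 log units; beyond the scatter). That expectation rests on the earlier step, a 2.9-fold lower number from compound 1 to compound 2 (0.47 log units; beyond the scatter), being carried over unchanged, and on compound 3 starting from 8210 nM, a number that lies within the scatter of compound 1. Among the compounds with values here, only one prior example of the change exists, so the carry-over is uncertain. In this assay compound 4 is estimated to give 2900 nM, with a likely range from 1200 nM to 7000 nM.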

Compound 4, concentration for 50% growth inhibition: 2310 nM
Compound 4: middle estimate off by 1.3-fold (0.10 log units), on the high side, within the range that was stated.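

In this assay the swap to 3-chlorophenyl on the hydroxy-bearing core gives a 3.6-fold lower number from compound 3 to compound 4 (0.55 log units; beyond the scatter) and so points the same way as on the methyl-bearing core, by an amount that cannot be told apart from the earlier step: the same change on two cores in this assay, a 2.9-fold lower number (0.47 log units; beyond the scatter) from compound 1 to compound 2 and a 3.6-fold lower number (0.55 log units; beyond the scatter) from compound 3 to compound 4, 1.2-fold (0.08 log units) apart, within the scatter of two such steps. Within this pair of cores, then, the size of the step measured on one core served as a fair guide to the size of the step on the other, even though the hydroxy and methyl groups sit on the benzimidazole in different places. Within the data shown here, this is still only two examples, so it sets no rule for other cores, and it cannot say why the numbers fall, since the swap removes the 4-(dimethylamino)phenyl group and brings in the 3-chlorophenyl group in a single move, leaving the part played by each unresolved.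

The compounds shown leave open whether the end ring could carry other groups, such as a nitrile, a carboxylic acid or a longer amine chain, with the same result on both cores. They also leave open whether the step would hold on a core bearing a methoxy group or an amine in place of the hydroxy.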